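Bromo for nitro on the shared core in mice

The source may report more compounds than this note shows. Statements on the series, on what has been measured and on what is new or still open speak of the compounds shown alone.

Measured compounds:
compound 1, `COc1cc2c(cc1OC)C(c1ccc([N+](=O)[O-])cc1)=NNC(=O)C2` — > 120 umol/kg
compound 2, `COc1cc2c(cc1OC)C(c1ccc(N)cc1)=NN=C(S)C2` — 6.3 umol/kg
compound 3, `COc1cc2c(cc1OC)C(c1ccc([N+](=O)[O-])cc1)=NN(C)C(=S)C2` — 103 umol/kg

The readout throughout is a functional assay on the whole organism with Mus musculus as the target; a lower number here means that less compound is needed, a higher number that more compound is needed for the effect. For compound 1 this assay gives only a limit, > 120 umol/kg; this is the edge of what the assay can report and not a number, as the limit of > 120 umol/kg in this assay, at which 1 of the 3 values shown sits, makes explicit. Compound 2 gives 6.3 umol/kg in this assay. Compound 3 gives 103 umol/kg in this assay. Among the compounds with values here, no single-point step between these three is recorded, so only the values themselves can be compared: compound 1 sits at the limit, compound 3 sits below it, and compound 2 sits well below both.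

Compound 4, `COc1cc2c(cc1OC)C(c1ccc(Br)cc1)=NNC(=O)C2`, is not yet measured in this assay. It differs from compound 1 by bromo in place of nitro on an aromatic carbon.

Since compound 1 only gives a limit, the size of the step to compound 4 cannot rest on a measured value. The account nevertheless expects the step to bring the number back inside the range of the assay, and the expected step is an at least 2.0-fold lower number from compound 1 to compound 4 (0.30 log units; that floor lies within the scatter). For compound 4 the estimate in this assay is 60 umol/kg, with a range from 20 umol/kg to 150 umol/kg.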

Compound 4, dose for half-maximal effect: 110 umol/kg
Beside the measured number, compound 4's estimate is 1.8-fold (0.26 log units) below it, and the stated range covers the measured number.
By their numbers in this assay, from the lowest: compound 2; then compounds 3 and 4 (each within the scatter of the next). At a limit, above all of these: compound 1.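

Bromo in place of nitro, on an aromatic carbon para to a large group, gives the first pair here that differs in one place, and in this assay compound 4 gives 110 umol/kg, a measured number rather than the edge of the read-out. On these data alone, the value of compound 1, > 120 umol/kg, is a limit and not a number: the limit of > 120 umol/kg in this assay, at which 1 of the 4 values shown sits. The step can be read only as an at least 1.0-fold lower number from compound 1 to compound 4 (0.03 log units; that floor lies within the scatter), so this swap on the shared core shows no change beyond the scatter, and its true size stays unknown.

As far as these compounds go, it remains open whether another group at this place, such as chloro or a nitrile, would move the number in this assay further than bromo does on the core of compound 1. From the compounds shown here alone, compound 2 carries its amino group together with a second change in the core, so what an amino group alone does at this place also remains open.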